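This account rests on a few compounds, and the source may have more. Where it says the series, first, only, none or still open, it means among the compounds named here.

Working notes on the series, read in a functional assay on HeLa cells (Homo sapiens) for cytotoxicity, read by MTT assay, with a stated time of 48 h; on this read-out higher numbers stand for weaker inhibition and lower numbers for stronger inhibition. Compound 1 (`COc1ccc(/C=C/c2cc(OC)c(OC)c(OC)c2-c2ccc(F)c(F)c2)cc1`) gives 9200 nM, and compound 2 (`C=C(c1ccc(OC)cc1)c1cc(OC)c(OC)c(OC)c1-c1ccc(F)c(F)c1`) gives 5900 nM. Within the data shown here, these are the only two values so far, and they lie within the scatter of each other, so compound 2 does not stand apart from compound 1. Among the measured compounds shown here, the one measured step is a 1.6-fold lower number from compound 1 to compound 2 (0.19 log units; within the scatter), which places 1-(4-methoxyphenyl)ethenyl where compound 1 has 2-(4-methoxyphenyl)ethenyl.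

Compound 3 (`C=C(c1ccc(OC)cc1)c1cc(OC)c(OC)c(OC)c1-c1ccc(Cl)cc1`) keeps the 1-(4-methoxyphenyl)ethenyl group of compound 2 and carries 4-chlorophenyl in place of 3,4-difluorophenyl on an aromatic carbon, ortho to that group: 4-chlorophenyl in place of 3,4-difluorophenyl on an aromatic carbon. For the measured compounds named here, no measured step covers this exchange. The step to compound 2 concerns another group, so it gives no size or direction here, and it only sets the level near compound 2 at 5900 nM. No shift beyond the scatter is therefore expected in this assay. The expected change is a 1.0-fold higher number from compound 2 to compound 3 (0.01 log units; within the scatter). For compound 3 the estimate is 6000 nM, with an expected range from 2500 nM to 14000 nM.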

Compound 3, half-maximal inhibitory concentration: 30000 nM
Compound 3: the middle estimate sits 5.0-fold (0.70 log units) below what was measured, outside the stated range (above it).
By their numbers in this assay, from the lowest: compounds 2 and 1 (each within the scatter of the next); then compound 3.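

This position is not indifferent to the group it carries. In this assay, on the aromatic carbon ortho to the 1-(4-methoxyphenyl)ethenyl group, 4-chlorophenyl in place of 3,4-difluorophenyl gives a 5.1-fold higher number from compound 2 to compound 3 (0.71 log units; beyond the scatter), the only step shown that lies beyond the scatter, and this exchange therefore moves the number where the earlier change of the ethenyl group did not. With two fluorine atoms leaving and one chlorine entering in a single exchange, this step cannot assign the shift to either change, and nothing measured here offers an explanation for it.

As far as these compounds go, it remains open whether the shift follows from the loss of fluorine or from the entry of chlorine, and how phenyl, 4-fluorophenyl, or a phenyl ring bearing an amine or a carboxylic acid would read at this position. From the compounds shown here alone, it also remains open whether the same exchange would move the number by a similar amount alongside the 2-(4-methoxyphenyl)ethenyl group of compound 1.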